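Oxygen-to-sulfur linker swap in the diaminoquinoxaline series

The source may hold more compounds than are shown below. What is called first, only, known or untested is meant among the compounds shown, and "the series" means these compounds.

Measured compounds:
compound 1 `Nc1cc(N)c2nc(-c3ccccc3)c(Oc3ccc(Cl)c(Cl)c3)nc2c1` — 70800 nM
compound 2 `CCOC(=O)[C@H](CCC(=O)O)NC(=O)c1ccc(Sc2nc3cc(N)cc(N)c3nc2-c2ccccc2)cc1` — < 100000 nM
compound 3 `CCOC(=O)[C@H](CCC(=O)O)NC(=O)c1ccc(Oc2nc3cc(N)cc(N)c3nc2-c2ccccc2)cc1` — < 100000 nM

In a functional assay on NCI-H460 cells (Homo sapiens) for inhibition, read by sulforhodamine B assay, with a stated time of 48 h (on this read-out lower numbers stand for stronger inhibition of growth and higher numbers for weaker inhibition of growth), compound 1 gives 70800 nM. This is the only numerical result in the set. Compound 2 is reported only as a limit, < 100000 nM, in this assay. Compound 3 is likewise reported only as a limit, < 100000 nM, in this assay. For the measured compounds named here, the two limits and the single number sit close together on the scale, so compound 1 cannot be placed as stronger or weaker than the other two; all that can be said is that its growth inhibition was resolved as a number while theirs were not (the limit of < 100000 nM in this assay, at which 2 of the 3 values shown sit).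

Compound 4 `Nc1cc(N)c2nc(-c3ccccc3)c(Sc3ccc(Cl)c(Cl)c3)nc2c1` has not been measured in this assay. It differs from compound 1 in one place: (3,4-dichlorophenyl)sulfanyl in place of 3,4-dichlorophenoxy on an aromatic carbon. The phenyl group on the shared core and the two amino groups are unchanged.

Going by the values given here, no measured pair in this set isolates a linker change, so the direction of this step cannot be read from the data. For compound 4 the expectation is a result of about 65000 nM, within 25000 nM to 150000 nM. The expected step of a 1.1-fold lower number from compound 1 to compound 4 (0.04 log units; within the scatter) is taken as none beyond the scatter, with a real chance that this assay again reports only a limit.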

Compound 4, concentration for total growth inhibition: 33900 nM
Beside the measured number, compound 4's estimate is 1.9-fold (0.28 log units) above it; the range from low to high includes it.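

In this assay, for the compounds shown here, (3,4-dichlorophenyl)sulfanyl in place of 3,4-dichlorophenoxy gives a 2.1-fold lower number from compound 1 to compound 4 (0.32 log units; beyond the scatter), the only readable linker change in the set and a modest one. This position, on an aromatic carbon next to the ring nitrogen and ortho to a phenyl group, therefore accepts sulfur in place of oxygen as the linking atom with a small gain in growth inhibition, and both compounds of the pair are resolved as numbers. The same oxygen-to-sulfur change separates compound 3 from compound 2, but that pair cannot be read, as each value is a limit and not a number: the limit of < 100000 nM in this assay, at which 2 of the 4 values shown sit.

A single readable pair does not show whether the step carries over to other groups on the linking atom, so the direction of the change holds for the 3,4-dichlorophenyl compounds alone. Also open, as far as these compounds go, is how a secondary amine or a sulfonyl linker would compare with the oxygen and sulfur linkers at this position on the shared core.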